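The source may hold more compounds than are shown below. What is called first, only, known or untested is meant among the compounds shown, and "the series" means these compounds.

Going by the values given here, in an ADME assay on microsomes from liver (Mus musculus) for metabolic stability, read by LC-MS, with a stated time of 1 h, tested at 5 uM (on this read-out higher numbers stand for a more stable compound and lower numbers for a less stable compound), three compounds have numbers so far. Compound 1 (`Cc1nc(-c2ccc(F)cc2)c(C(=O)N2CCN(c3cc(Cl)cc(Cl)c3)CC2)o1`) gives 31.1% and compound 3 (`Cc1nc(-c2ccccc2)c(C(=O)N2CCN(c3cc(Cl)cc(Cl)c3)CC2)o1`) gives 43.4% while compound 2 (`COc1cc(OC)cc(N2CCN(C(=O)c3oc(C)nc3-c3ccc(F)cc3)CC2)c1`) gives 5.6% as the lowest of the three. Compound 4 (`COc1cc(OC)cc(N2CCN(C(=O)c3oc(C)nc3-c3cccc(F)c3)CC2)c1`) differs from compound 2 in one place (3-fluorophenyl in place of 4-fluorophenyl on an aromatic carbon) with 3-fluorophenyl in place of 4-fluorophenyl on an aromatic carbon. Among the compounds with values here, no measured step moves a fluoro group on its ring, so nothing matches this change directly. The nearest evidence is the loss of fluoro (a number 12.3 percentage points higher from compound 1 to compound 3 (beyond the scatter)), a modest step beyond the scatter, seen with 3,5-dichlorophenyl rather than 3,5-dimethoxyphenyl on the amine nitrogen. The larger step (a number 25.5 percentage points lower from compound 1 to compound 2 (beyond the scatter)) concerns that amine substituent, which compound 4 shares with compound 2, so it does not bear on this change. Compound 4 keeps its fluoro, so a step smaller than the one on losing fluoro is expected. The expected change is small (a number 2.4 percentage points higher from compound 2 to compound 4 (within the scatter)) and not beyond the scatter, with a slight lean upward. In this assay the estimated value for compound 4 is 8% (from 2% to 20%).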

Compound 4, percent of the compound remaining: 11.6%
Beside the measured number, compound 4's estimate is 3.6 percentage points below it; measured number inside the range.
By their numbers in this assay, from the lowest: compounds 2 and 4 (each within the scatter of the next); then compound 1; then compound 3.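

Moving the fluoro group from 4-fluorophenyl to 3-fluorophenyl on this aromatic carbon, on a five-membered aromatic ring with 1 nitrogen and 1 oxygen, gives in this assay a number 6 percentage points higher from compound 2 to compound 4 (within the scatter). Going by these compounds alone, this is the first reading of where the fluoro group sits on this phenyl ring, and with 3,5-dimethoxyphenyl on the amine nitrogen the two placements cannot be told apart in this read-out. No evidence at hand bears on why this is so.

The compounds shown leave open whether the two placements would also read alike with 3,5-dichlorophenyl on the amine nitrogen, where the loss of fluoro gave a step beyond the scatter. They also leave open how another group at this place, such as 3-chlorophenyl or 3-methoxyphenyl, would read.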